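Ketal side chain: bromide replaced by methylpiperazine

A few compounds are considered here, and "the series" means these few. Any claim that something is new, unique, unknown or untested is made for them only; others in the source may bear on it.

For the measured compounds named here, compound 1 `CCC(C)n1ncn(-c2ccc(N3CCN(c4ccc(OC[C@@H]5CO[C@@](CBr)(c6ccc(Cl)cc6Cl)O5)cc4)CC3)cc2)c1=O` gives 569 nM in a functional assay on HUVEC cells (Homo sapiens), read by scintillation counting and thymidine incorporation, with a stated time of 24 h (a lower number here means a stronger inhibitor, a higher number a weaker inhibitor), the lower of the two numbers in hand, though the only neighbour, compound 2 `CCC(C)n1ncn(-c2ccc(N3CCN(c4ccc(OC[C@@H]5CO[C@@](CN6CCNCC6)(c6ccc(Cl)cc6Cl)O5)cc4)CC3)cc2)c1=O` with 608 nM, sits within the scatter of it. Going by the values given here, the single measured step, a 1.1-fold higher number from compound 1 to compound 2 (0.03 log units; within the scatter), puts piperazin-1-yl in place of bromo on a saturated chain carbon bound to a saturated ring carbon and leaves the number essentially where it was. Compound 3 `CCC(C)n1ncn(-c2ccc(N3CCN(c4ccc(OC[C@@H]5CO[C@@](CN6CCN(C)CC6)(c6ccc(Cl)cc6Cl)O5)cc4)CC3)cc2)c1=O` is not yet measured; it differs from compound 1 thus: 4-methylpiperazin-1-yl in place of bromo on a saturated chain carbon bound to a saturated ring carbon. Among the compounds with values here, the entering group is the piperazine of compound 2 carrying a methyl, so the step from compound 1 to compound 2 is the only comparison that bears on it, and that step was flat. No step beyond the scatter is therefore expected in this assay, that is a 1.1-fold higher number from compound 1 to compound 3 (0.02 log units; within the scatter). Compound 3 is expected to give 600 nM, within a range of 250 nM to 1500 nM.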

Compound 3, half-maximal inhibitory concentration: 396 nM
Beside the measured number, compound 3's estimate is 1.5-fold (0.18 log units) above it; low and high end bracket the measured number.
By their numbers in this assay, from the lowest: compounds 3, 1 and 2 (each within the scatter of the next).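

At the saturated chain carbon bound to a saturated ring carbon, 4-methylpiperazin-1-yl is a second replacement for bromo that stays within the scatter in this assay, with a 1.4-fold lower number from compound 1 to compound 3 (0.16 log units; within the scatter) and a group of 7 heavy atoms entering for a single one. The new point concerns the amine nitrogen in a ring: methyl in place of hydrogen there gives a 1.5-fold lower number from compound 2 to compound 3 (0.19 log units; within the scatter), so this pair shows no readable effect of that substitution. No measurement on hand offers an explanation for either step.

Still open, going by these compounds, is whether a different kind of group at this place, such as morpholine, a primary amine or a carboxylic acid, would move the number beyond the scatter. Also open, on these data alone, is whether an ethyl, a longer chain or an acetyl on the piperazine nitrogen would do so.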